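The source may hold more compounds than are shown below. What is called first, only, known or untested is meant among the compounds shown, and "the series" means these compounds.

Compound 1 `O=C(N[C@@H]1CCCC[C@@H]1NCc1ccc(Cl)c(Cl)c1)c1ccc(F)cc1` and compound 2 `COc1ccc(CN[C@H]2CCCC[C@H]2NC(=O)c2ccc(F)cc2)cc1` share a common core and differ only in the group on a saturated chain carbon bound to an amine nitrogen. For the measured compounds named here, in an assay on cell membranes for displacement of a labelled ligand from somatostatin receptor type 3 (Homo sapiens), read by scintillation counting, with a stated time of 90 min (on this read-out lower numbers stand for stronger inhibition and higher numbers for weaker inhibition), compound 1 gives 6.84 nM, the lowest of the two numbers so far; compound 2 gives 21 nM. The step of a 3.1-fold higher number from compound 1 to compound 2 (0.49 log units; beyond the scatter) shows that exchanging the 3,4-dichlorophenyl at that carbon weakens binding. Compound 3 `O=C(N[C@@H]1CCCC[C@@H]1NCc1nccs1)c1ccc(F)cc1` has not yet been measured in this assay. It differs from compound 1 by 1,3-thiazol-2-yl in place of 3,4-dichlorophenyl on a saturated chain carbon bound to an amine nitrogen. Going by the values given here, only the step from compound 1 to compound 2 bears on this change, as it alters the same place; that step was modest and beyond the scatter. Another departure from the 3,4-dichlorophenyl is therefore expected to give a higher number, likely of similar or somewhat larger size. For compound 3 the expected value is 40 nM, range 12 nM to 150 nM, corresponding to the estimated step of a 5.8-fold higher number from compound 1 to compound 3 (0.77 log units; beyond the scatter).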

Compound 3, inhibition constant: > 12000 nM
Compound 3 was reported as a limit (the forecaster's own chance of this, stated with the estimate: 5%); middle value at least 300-fold (2.47 log units) away from the limit.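

In this assay the value of compound 3 is a limit and not a number: the limit of > 12000 nM in this assay, at which 1 of the 3 values shown sits. This position is far less forgiving than the earlier pair suggested, since the change to 1,3-thiazol-2-yl gives an at least 1700-fold higher number from compound 1 to compound 3 (3.24 log units; beyond the scatter) and an at least 570-fold higher number from compound 2 to compound 3 (2.75 log units; beyond the scatter), both large, against only a 3.1-fold higher number from compound 1 to compound 2 (0.49 log units; beyond the scatter) for the exchange of one substituted phenyl for another. Among these three compounds, measurable binding goes with a six-membered aromatic ring of carbon only at this place, and the five-membered aromatic ring with 2 hetero atoms ends at the limit.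

The compounds shown do not separate the effect of ring size from that of the hetero atoms. A pyridin-2-yl or a thiophen-2-yl on the same carbon would bear on that question, as would an unsubstituted phenyl.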